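Furan-2-yl for 2,4-difluorophenyl under a cytotoxicity limit

The compounds below may be only part of what the source reports. "The series", "measured", "known", "first", "only" and "open" are said of these compounds alone.

Of the compounds shown here, two on a shared core have been tested in an ADME assay on HepG2 cells (Homo sapiens) for cytotoxicity, read by MTT assay, with a stated time of 72 h; on this read-out lower numbers stand for higher toxicity in this test and higher numbers for lower toxicity in this test. Compound 1 (`O=[N+]([O-])c1c(CS(=O)(=O)c2ccccc2)nc2c(-c3ccccc3F)cc(Cl)cn12`) returned only a limit, > 3900 nM. Compound 2 (`O=[N+]([O-])c1c(CS(=O)(=O)c2ccccc2)nc2c(-c3ccc(F)cc3F)cc(Cl)cn12`) likewise returned only a limit, > 7800 nM, so no actual number fixes where it stands. Compound 3 (`O=[N+]([O-])c1c(CS(=O)(=O)c2ccccc2)nc2c(-c3ccco3)cc(Cl)cn12`) has not yet been measured. It departs from compound 2 at a single place, an aromatic carbon meta to a chloro group, and the change is furan-2-yl in place of 2,4-difluorophenyl on an aromatic carbon. In words, furan-2-yl stands in place of 2,4-difluorophenyl on an aromatic carbon.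

Among the compounds with values here, only one measured step bears on this change, and it does so loosely: a step that the two limits leave unreadable from compound 1 to compound 2, for a fluoro in place of hydrogen on an aromatic carbon. That step has no readable size to carry over, so the expectation in this assay is no step beyond the scatter, in neither direction. The expected move is a step that the limit leaves unreadable from compound 2 to compound 3, and this is an estimate only. A further limit rather than a number would be no surprise. For compound 3 the estimated value is 10000 nM, with an expected range from 3500 nM to 30000 nM.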

Compound 3, half-maximal cytotoxic concentration: > 3900 nM
Compound 3 ended at the assay's limit (the forecaster's own chance of this, stated with the estimate: 60%); the middle value lies beyond the limit too.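

In this assay, compound 1, compound 2 and compound 3 each returned only a limit and not a number, so none of the steps among them can be read. Going by these compounds, it remains open where any of the three actually stands, and whether furan-2-yl in place of 2,4-difluorophenyl shifts the read-out at all.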